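Working notes: from compound 3 to compound 4

This account rests on a few compounds, and the source may have more. Where it says the series, first, only, none or still open, it means among the compounds named here.

Of the compounds shown here, three have been read in a functional assay on HCT-116 cells (Homo sapiens); a higher number here means a weaker inhibitor, a lower number a stronger inhibitor. Compound 1 (`COc1cc(NC(C)CCCNC(=O)NCCCO)c2ncccc2c1`) gives > 100000 nM, which is a limit of the assay and not a number. Compound 2 (`COc1cc(NC(C)CCCNC(=O)NCCCCCO)c2ncccc2c1`) gives 29000 nM. Compound 3 (`COc1cc(NC(C)CCCNC(=O)NOCc2ccccc2)c2ncccc2c1`) gives 14000 nM, the lower of the two actual numbers and the strongest inhibitor of the three.

In compound 4 (`COc1cc(NC(C)CCCNC(=O)NC(CO)(CO)CO)c2ncccc2c1`), 2-hydroxy-1,1-bis(hydroxymethyl)ethyl stands in place of benzyloxy on an amide-type nitrogen (2-hydroxy-1,1-bis(hydroxymethyl)ethyl in place of benzyloxy on an amide-type nitrogen).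

Two measured steps make the reverse kind of exchange, bringing benzyloxy in where a hydroxy-bearing group stood. One is a 2.1-fold lower number from compound 2 to compound 3 (0.32 log units; beyond the scatter), with benzyloxy in place of 5-hydroxypentyl. The other is an at least 7.1-fold lower number from compound 1 to compound 3 (0.85 log units; beyond the scatter), with benzyloxy in place of 3-hydroxypropyl. Among the hydroxy-bearing groups, the shorter one sits at the weaker end, as an at least 3.4-fold lower number from compound 1 to compound 2 (0.53 log units; beyond the scatter) shows. The entering group has no ring and is a new type, so these steps guide direction more than size.

Removing benzyloxy is therefore expected to move the number upward in this assay, by a step beyond the scatter. The expected step is a 5.0-fold higher number from compound 3 to compound 4 (0.70 log units; beyond the scatter). Compound 4 is estimated at 70000 nM, with an expected range of 25000 nM to 200000 nM.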

Compound 4, half-maximal inhibitory concentration: > 100000 nM
Compound 4: no number, only a limit (the forecaster's own chance of this, stated with the estimate: 55%); middle value at least 1.4-fold (0.15 log units) from the limit.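

In this assay compound 4 gives > 100000 nM, which is a limit of the assay and not a number. Among these compounds, on the amide-type nitrogen, 2-hydroxy-1,1-bis(hydroxymethyl)ethyl gives an at least 7.1-fold higher number from compound 3 to compound 4 (0.85 log units; beyond the scatter) and an at least 3.4-fold higher number from compound 2 to compound 4 (0.53 log units; beyond the scatter), so this branched group with no ring joins 3-hydroxypropyl at the weak end of the series, while benzyloxy and 5-hydroxypentyl remain the only groups here with actual numbers. The step between compound 1 and compound 4 cannot be read because both compounds sit at the limit, so the two groups cannot be ranked against each other: the limit of > 100000 nM in this assay, at which 2 of the 4 values shown sit.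

What the compounds shown leave open is whether the gain with benzyloxy belongs to its aromatic ring or to the oxygen that joins it to the amide-type nitrogen, a question that a plain benzyl group on the same nitrogen would address. On these data alone, it also remains open whether a longer chain than 5-hydroxypentyl, or one ending in an amine or a carboxylic acid instead of hydroxy, would lower the number further.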